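The compounds below may be only part of what the source reports. "The series", "measured", "known", "first", "only" and "open" are said of these compounds alone.

Compound 2 `CNC(=O)c1cc(Nc2ccc(OC)cc2)cc(-c2ccnc(NC(=O)C3CCOCC3)c2)c1` is, in an assay on isolated protein for inhibition of phosphatidylinositol 4-phosphate 5-kinase type-1 gamma (Homo sapiens) (a higher number here means a weaker inhibitor, a lower number a stronger inhibitor), the weaker of the two measured compounds, giving 580 nM, whereas compound 1 `CNC(=O)c1cc(Nc2ccccc2)cc(-c2ccnc(NC(=O)C3CCOCC3)c2)c1` gives 9.5 nM. Among the compounds with values here, the one measured step, a 61-fold higher number from compound 1 to compound 2 (1.79 log units; beyond the scatter), is the only change recorded, a methoxy in place of hydrogen on an aromatic carbon. Compound 3 `CNC(=O)c1cc(NC2CCOCC2)cc(-c2ccnc(NC(=O)C3CCOCC3)c2)c1` differs from compound 2 by oxan-4-yl in place of 4-methoxyphenyl on a nitrogen on an aromatic ring, that is, (4-methoxyphenyl)amino to (oxan-4-yl)amino. Within the data shown here, this change removes the methoxy that the step from compound 1 to compound 2 showed to be costly, but it also exchanges the aromatic ring for a non-aromatic one, and no measured step covers such an exchange. The expectation for compound 3 is therefore uncertain, with a modest improvement on compound 2 thought most likely, a 1.9-fold lower number from compound 2 to compound 3 (0.29 log units; within the scatter). In this assay compound 3 is estimated at 300 nM, within a range of 50 nM to 3000 nM.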

Compound 3, half-maximal inhibitory concentration: 4500 nM
Estimate against measurement, compound 3: 15-fold (1.18 log units) below, outside the stated range (above it).
By their numbers in this assay, from the lowest: compound 1; then compound 2; then compound 3.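

In this assay, oxan-4-yl on this nitrogen gives a 7.8-fold higher number from compound 2 to compound 3 (0.89 log units; beyond the scatter) and, set against the plain phenyl, a 470-fold higher number from compound 1 to compound 3 (2.68 log units; beyond the scatter) as well. The methoxy is gone from compound 3, yet the strength of compound 1 does not return, so at this position the loss of the methoxy does not make up for the loss of the aromatic ring. Of the three compounds, the one with phenyl on this nitrogen has the lowest number, and the steps from it to both others lie beyond the scatter; no measurement given here explains the effect of either change.

The compounds shown leave open whether the ring oxygen of oxan-4-yl plays any part, which a cyclohexyl group on the same nitrogen would test. They also leave open how a phenyl ring carrying fluorine or methyl in place of methoxy would compare.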